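Amide-side variation from compound 2 to compound 3

The source may hold more compounds than are shown below. What is called first, only, known or untested is meant among the compounds shown, and "the series" means these compounds.

Compound 2 `COc1cccc(-c2nc(SC)nc3sc(C(=O)NCCO)c(N)c23)c1` and compound 1 `COc1cccc(-c2nc(SC)nc3sc(C(=O)NNC(C)(C)C)c(N)c23)c1` lie within the scatter of each other in a functional assay on HEK293 cells for agonist activity at Thyrotropin receptor (Homo sapiens), read by cAMP accumulation; on this read-out higher numbers stand for larger maximal responses and lower numbers for smaller maximal responses: compound 2 gives 2.9% and compound 1 gives 6.4%, both small maximal responses. Among the compounds with values here, the single measured step, a number 3.5 percentage points lower from compound 1 to compound 2 (within the scatter), also changed the substituent on the amide-type nitrogen and caused no shift beyond the scatter. Compound 3 `COc1cccc(-c2nc(SC)nc3sc(C(=O)NCc4ccccc4)c(N)c23)c1` differs from compound 2 by phenyl in place of hydroxymethyl on a saturated chain carbon bound to an amide-type nitrogen. Given the flat step a number 3.5 percentage points lower from compound 1 to compound 2 (within the scatter), no step beyond the scatter is expected here either. Compound 3 is estimated at 7%, with a range from 0% to 25%, an expected step of a number 4.1 percentage points higher from compound 2 to compound 3 (within the scatter).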

Compound 3, largest response reached (reported as efficacy), in percent of the reference or control that the assay uses: 3%
Beside the measured number, compound 3's estimate is 4 percentage points above it; the measured number falls inside the stated range.
By their numbers in this assay, from the lowest: compounds 2, 3 and 1 (each within the scatter of the next).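

Replacing hydroxymethyl with phenyl on the saturated chain carbon brings in a six-membered aromatic ring and removes the hydroxymethyl hydrogen-bond donor and acceptor, yet this assay shows a number 0.1 percentage points higher from compound 2 to compound 3 (within the scatter). Benzyl in place of (tert-butyl)amino on the amide-type nitrogen gives a number 3.4 percentage points lower from compound 1 to compound 3 (within the scatter), so these three amide substituents cannot be told apart on this read-out. No outside evidence bears on this result.

Open, going by these compounds, is whether an aminoethyl or carboxymethyl group on the amide-type nitrogen, or a longer chain such as 2-phenylethyl, would move the maximal response beyond the scatter. The compounds shown also say nothing about changes away from the amide.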